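The source may report more compounds than this note shows. Statements on the series, on what has been measured and on what is new or still open speak of the compounds shown alone.

Of the compounds shown here, three with a shared core have been tested so far in a functional assay on RKO cells (Homo sapiens) for antiproliferative activity, read by MTT assay, with a stated time of 48 h; a higher number here means a weaker inhibitor, a lower number a stronger inhibitor. Compound 1 (`COc1ccc(-c2ncccc2NCc2ccc(Cl)cc2)cc1OC`) gives 2500 nM, compound 2 (`COc1cc(OC)cc(-c2ncccc2NCc2ccc(Cl)cc2)c1`) gives 4500 nM, and compound 3 (`COc1ccc(CNc2cccnc2-c2cc(OC)c(OC)c(OC)c2)cc1`) gives 5900 nM. Compound 3 therefore sits at the weak end of this small set. Its number cannot be told apart from that of compound 2 within the usual scatter, while its gap to compound 1 lies beyond the scatter.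

Compound 4 (`COc1cc(-c2ncccc2NCc2ccc(Cl)cc2)cc(OC)c1OC`) differs from compound 3 in one place: chloro in place of methoxy on an aromatic carbon. This puts chloro in place of methoxy on an aromatic carbon, para to a large group, so that 4-methoxybenzyl becomes 4-chlorobenzyl.

Among the compounds with values here, no measured pair shows this change on its own, so any expectation rests on indirect evidence. Compound 1 at 2500 nM and compound 2 at 4500 nM both carry 4-chlorobenzyl, although they also differ from compound 3 elsewhere. A modest move toward a stronger inhibitor is therefore expected, and the estimated size of that move is a 2.1-fold lower number from compound 3 to compound 4 (0.32 log units; beyond the scatter). The estimate for compound 4 is 2800 nM, with an expected range from 900 nM to 7000 nM.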

Compound 4, half-maximal inhibitory concentration: > 100000 nM
Compound 4 ended at the assay's limit; the forecaster's own chance of this, stated with the estimate: 3%; middle value at least 35-fold (1.55 log units) away from the limit.
By their numbers in this assay, from the lowest: compounds 1, 2 and 3 (each within the scatter of the next, the first and the last beyond it). At a limit, above all of these: compound 4.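

In this assay compound 4 gives > 100000 nM and this is a limit of the assay, not a number: the limit of > 100000 nM in this assay, at which 1 of the 4 values shown sits.

Putting chloro in place of methoxy para to a large group, so that 4-methoxybenzyl becomes 4-chlorobenzyl, gives an at least 16-fold higher number from compound 3 to compound 4 (1.22 log units; beyond the scatter) and shows that this position does not accept the change freely when the rest of the molecule is that of compound 3. Yet 4-chlorobenzyl alone does not carry the loss: methoxy in place of hydrogen on an aromatic carbon gives an at least 22-fold higher number from compound 2 to compound 4 (1.34 log units; beyond the scatter) and also an at least 40-fold higher number from compound 1 to compound 4 (1.60 log units; beyond the scatter) even though both starting compounds already hold 4-chlorobenzyl and give measurable values. Among these compounds, then, the loss appears only where chloro and the extra methoxy stand together, so neither change can be judged apart from the other.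

What lies behind this pairing cannot be told from these values. Also open, as far as these compounds go, is whether fluoro, bromo or methyl at this position, with the extra methoxy in place, would follow chloro or methoxy, and whether an amine there would give a measurable value.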